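The source may hold more compounds than are shown below. What is called first, only, known or untested is meant among the compounds shown, and "the series" means these compounds.

Measured compounds:
- compound 1, `CC(=O)N[C@@H]1CCCc2c1cncc2N1C(=O)c2ccc(Cl)cc2[C@H]1C`, an ADME assay on microsomes from liver (Mus musculus) for metabolic stability, read by LC-MS, using NADPH, with stated times of 10 min and 30 min; a higher number here means faster removal of the compound, a lower number slower removal: 43.5 mL/min/kg
- compound 2, `N#Cc1ccc2c(c1)CN(c1cccnc1)C2=O`, this assay: 45.6 mL/min/kg
- compound 3, `CCC(=O)N[C@@H]1CCCc2c1cncc2N1C(=O)c2ccc(Cl)cc2[C@H]1CC`, this assay: 44.9 mL/min/kg

Of the compounds shown here, three have numbers so far, and the three numbers do not separate from one another: the nearest to compound 1 is compound 3 and the furthest is compound 2, and both gaps lie within the scatter of repeated measurements. Compound 1 therefore stands on a level shared by the whole set, and no pair of these compounds shows a step that can be read as a real difference in clearance.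

Compound 4, `CC(=O)N[C@@H]1CCCc2c1cncc2N1Cc2cc(Cl)ccc2C1=O`, is not yet measured in this assay. It differs from compound 1 by hydrogen in place of methyl on a saturated ring carbon. Among the measured compounds shown here, no step between measured compounds of this kind is available, so the expectation can only rest on the measured spread: all three numbers sit together, and compound 2, which also carries a hydrogen on the saturated ring carbon of its five-membered ring, gives 45.6 mL/min/kg, on the same level as the others.

The step from compound 1 to compound 4 in this assay is expected to be a 1.0-fold higher number from compound 1 to compound 4 (0.00 log units; within the scatter), that is, none beyond the scatter. Compound 4 is estimated at 44 mL/min/kg, with a range from 25 mL/min/kg to 78 mL/min/kg.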

Compound 4, clearance: < 20.2 mL/min/kg
Compound 4 gave a limit, no number; the forecaster's own chance of this, stated with the estimate: 2%; middle value at least 2.1-fold (0.33 log units) away from the limit.
By their numbers in this assay, from the lowest: compounds 1, 3 and 2 (each within the scatter of the next). At a limit, below all of these: compound 4.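

Hydrogen in place of methyl on a saturated ring carbon, next to the ring nitrogen and next to the ring atom that bears a large group, gives the first step in the series that can be read in this assay: an at least 2.1-fold lower number from compound 1 to compound 4 (0.33 log units; beyond the scatter). Compound 4 stands as a limit and not as a number: the limit of < 20.2 mL/min/kg in this assay, at which 1 of the 4 values shown sits. Among the compounds shown here, this position is therefore one where a single change moves the reading beyond the scatter, something the earlier compounds, with no step between them, could not show, although the step fixes only a bound and not a size.

How far compound 4 lies past its limit remains open, and the compounds shown give no measured property that would explain the step, so it stands as an observation about this one change. Also open, from the compounds shown here alone, is whether a hydroxyl, a fluorine or an amine on this same ring carbon would read like compound 1 or like compound 4 in this assay, and so whether the step depends on the methyl leaving or on what takes its place.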